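This account rests on a few compounds, and the source may have more. Where it says the series, first, only, none or still open, it means among the compounds named here.

In an ADME assay on H1-HeLa cells (Homo sapiens) for cytotoxicity, read by MTT assay, with a stated time of 3 days (on this read-out lower numbers stand for higher toxicity in this test and higher numbers for lower toxicity in this test), compound 1 `CCOC(=O)c1cc2ccc(Oc3ccnc(C(=O)NC)c3)cc2s1` gives > 100000 nM, which is a limit of the assay. Compound 2 `CNC(=O)c1cc(Oc2ccc3cc(C(=O)OC)sc3c2)ccn1` gives > 100000 nM, again a limit. Within the data shown here, compound 3 `CCCOC(=O)c1sc2cc(Oc3ccnc(C(=O)NC)c3)ccc2c1C` gives 37400 nM, the only actual number in the set. Compound 4 `CNC(=O)c1cc(Oc2ccc3c(C)c(C(=O)N(C)C)sc3c2)ccn1` differs from compound 3 by one change: dimethylamino in place of propoxy on a carbonyl carbon. Among the measured compounds shown here, the only measured step is a step that the two limits leave unreadable from compound 1 to compound 2, so it offers no size to carry over, and no measured step covers dimethylamino in place of propoxy. The expectation therefore starts from compound 3 at 37400 nM, with no step beyond the scatter expected in this assay. The expected change is a 1.2-fold higher number from compound 3 to compound 4 (0.08 log units; within the scatter), with no firm direction. For compound 4 the estimated value is 45000 nM, within an expected range of 18000 nM to 110000 nM.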

Compound 4, half-maximal cytotoxic concentration: 42500 nM
Compound 4: middle estimate off by 1.1-fold (0.02 log units), on the high side; the range from low to high includes it.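

In this assay, dimethylamino on the carbonyl carbon reads much like propoxy: a 1.1-fold higher number from compound 3 to compound 4 (0.06 log units; within the scatter). This is the only step shown with a readable size, as the step between the two compounds at the limit cannot be read. It shows that going from propoxycarbonyl to dimethylcarbamoyl stays within the scatter at this place, and it gives a second actual number at this position.

The compounds shown leave open how a carboxylic acid or a cyclic amine on this carbonyl carbon would read. Comparison at the high end of the scale also remains limited: the limit of > 100000 nM in this assay, at which 2 of the 4 values shown sit.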